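Methoxy in Place of Methyl on a Branched Anilide

The compounds below may be only part of what the source reports. "The series", "measured", "known", "first", "only" and "open" are said of these compounds alone.

Compound 1 `CCCCCCCCCCC(C)(C)C(=O)Nc1ccc(C)cc1C`: 680 nM
Compound 2 `CCCCCCCCCCC(C)(C)C(=O)Nc1c(C)cccc1C`: 1300 nM

Both measured compounds share a long branched acyl chain on an amide nitrogen and differ only in where the two methyl groups sit on the aromatic ring. In an assay on microsomes from intestine for inhibition of acyl-CoA:cholesterol acyltransferase (Oryctolagus cuniculus) (a higher number here means a weaker inhibitor, a lower number a stronger inhibitor), compound 2 gives 1300 nM, the higher of the two numbers, while compound 1 gives 680 nM; the step of a 1.9-fold higher number from compound 1 to compound 2 (0.28 log units; within the scatter) lies within the scatter, so the two compounds cannot be told apart on these data.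

Compound 3 `CCCCCCCCCCC(C)(C)C(=O)Nc1c(C)cccc1OC` follows from compound 2 by methoxy in place of methyl on an aromatic carbon. Going by the values given here, no measured step exchanges a methyl for a methoxy, so nothing recorded here bears directly on this change; the only step available, the repositioning of a methyl in a 1.9-fold higher number from compound 1 to compound 2 (0.28 log units; within the scatter), was itself small. A step of similar size, in either direction or none beyond the scatter, is therefore expected.

Compound 3 is estimated at 1300 nM in this assay, with a range from 450 nM to 3800 nM. This estimate corresponds to an expected step of no change at the digits printed from compound 2 to compound 3 (within the scatter).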

Compound 3, half-maximal inhibitory concentration: 210 nM
For compound 3 the middle estimate is 6.2-fold (0.79 log units) above the measured one; the whole stated range lies above it.
By their numbers in this assay, from the lowest: compound 3; then compounds 1 and 2 (each within the scatter of the next).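

In this assay methoxy in place of methyl on this aromatic carbon, ortho to a large group, gives a 6.2-fold lower number from compound 2 to compound 3 (0.79 log units; beyond the scatter) and so separates two compounds by more than the scatter, which the earlier pair, differing only in where the methyl groups sit, did not do. The substituent at this position therefore matters to the read-out in a way that the first two compounds could not reveal, at least with the other methyl group and the branched acyl chain held as they are in compound 2. Methoxy brings an oxygen and a hydrogen-bond acceptor that methyl lacks, but nothing measured here indicates which feature of the exchange, if either, accounts for the lower number.

The compounds shown leave open whether a hydroxy, an ethoxy or a chlorine at this position would shift the number in the same direction, and whether the same exchange would hold on the ring pattern of compound 1. They also leave open how a shorter chain would alter the result, as the long branched acyl chain stays the same in all three compounds.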